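The compounds below may be only part of what the source reports. "The series", "measured", "known", "first", "only" and "open" are said of these compounds alone.

Compound 3 `O=C(OC[C@H]1CN(c2ccc(-n3cc(-c4ccccn4)cn3)c(F)c2)C(=O)O1)c1ccccc1` gives > 400 ug/mL in an ADME assay on HEK293-A cells (Homo sapiens) for cytotoxicity, read by MTT assay, with a stated time of 48 h (on this read-out higher numbers stand for weaker inhibition and lower numbers for stronger inhibition), which is a limit of the assay rather than a number. Compound 1 `CN(CCC#N)C[C@H]1CN(c2ccc(-n3cc(-c4ccccn4)cn3)c(F)c2)C(=O)O1` likewise gives > 400 ug/mL, again a limit. For the measured compounds named here, compound 2 `CN1CCN(C[C@H]2CN(c3ccc(-n4cc(-c5ccccn5)cn4)c(F)c3)C(=O)O2)CC1` is the one member with a read number, 70 ug/mL. The measured steps show an at least 5.7-fold lower number from compound 1 to compound 2 (0.75 log units; beyond the scatter) and an at least 5.7-fold higher number from compound 2 to compound 3 (0.75 log units; beyond the scatter), while a step that the two limits leave unreadable from compound 1 to compound 3; the shared limit of > 400 ug/mL in this assay, at which 2 of the 3 values shown sit, keeps those two values from being separated. Compound 4 `O=C1O[C@@H](Cn2ccnn2)CN1c1ccc(-n2cc(-c3ccccn3)cn2)c(F)c1` differs from compound 3 by 1H-1,2,3-triazol-1-yl in place of benzoyloxy on a saturated chain carbon bound to a saturated ring carbon. Going by the values given here, no measured step exchanges these two groups, and the two limited compounds give no scale for a change of this kind. Compound 4 is therefore expected to give 350 ug/mL in this assay, with a range from 150 ug/mL to 400 ug/mL. That estimate means an at least 1.1-fold lower number from compound 3 to compound 4 (0.05 log units; that floor lies within the scatter), most likely ending again at the limit.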

Compound 4, half-maximal inhibitory concentration: 225 ug/mL
For compound 4 the middle estimate is 1.6-fold (0.19 log units) above the measured one; low and high end bracket the measured number.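

In this assay, 1H-1,2,3-triazol-1-yl in place of 4-methylpiperazin-1-yl gives a 3.2-fold higher number from compound 2 to compound 4 (0.51 log units; beyond the scatter), so this saturated chain carbon now carries two read numbers that stand apart, rather than one read number and limits. Against the two compounds held at a limit, only floors can be given, an at least 1.7-fold lower number from compound 3 to compound 4 (0.24 log units; that floor lies within the scatter) and an at least 1.7-fold lower number from compound 1 to compound 4 (0.24 log units; that floor lies within the scatter): the limit of > 400 ug/mL in this assay, at which 2 of the 4 values shown sit.

The compounds shown leave open how a primary amine, a carboxylic acid or a 1H-1,2,4-triazol-1-yl group would read at this place. They also leave open how far the benzoyloxy and (2-cyanoethyl)(methyl)amino compounds truly lie from compound 4.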